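The source may report more compounds than this note shows. Statements on the series, on what has been measured and on what is new or still open speak of the compounds shown alone.

Measured compounds:
compound 1 `O=C(CN(c1nc(Cl)nc2c1ncn2C1CCCCO1)C1CC1)N[C@@H](CC(=O)OCc1ccccc1)C(=O)OCc1ccccc1` — 25.1%
compound 2 `CSCC[C@H](NC(=O)CN(c1nc(Cl)nc2c1ncn2C1CCCCO1)C1CC1)C(=O)OCc1ccccc1` — 42.7%

In a functional assay on the whole organism with Mus musculus as the target, with a stated time of 90 min, at a dose of 25 umol/kg by the oral route (a lower number here means a weaker effect, a higher number a stronger effect of the compound at the dose given), compound 2 stands highest of the two numbers; compound 1 is its nearest neighbour, and the step of a number 17.6 percentage points higher from compound 1 to compound 2 (beyond the scatter) lies beyond the scatter. Compound 3 `O=C(CN(c1nc(Cl)nc2c1ncn2C1CCCCO1)C1CC1)N[C@@H](CO)C(=O)OCc1ccccc1` differs from compound 2 by hydroxy in place of (methylsulfanyl)methyl on a saturated chain carbon, two bonds along the chain from an amide-type nitrogen and a carbonyl carbon. Going by the values given here, no measured step exchanges the (methylsulfanyl)methyl group for hydroxy; the only step known at this position, a number 17.6 percentage points higher from compound 1 to compound 2 (beyond the scatter), shows that a change here can move the read-out by a modest amount in either direction. The expected step is therefore a number 9.7 percentage points lower from compound 2 to compound 3 (within the scatter), a small drop inside a wide range. For compound 3 the estimated value in this assay is 33%, with the range 12% to 55%.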

Compound 3, a percentage reported as activity, at one dose (the size of the read-out at that dose, not a potency): 32.2%
Compound 3: the middle estimate sits 0.8 percentage points above what was measured; the range from low to high includes it.
By their numbers in this assay, from the lowest: compounds 1 and 3 (each within the scatter of the next); then compound 2.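

In this assay, hydroxy in place of (methylsulfanyl)methyl gives a number 10.5 percentage points lower from compound 2 to compound 3 (beyond the scatter), so compound 2 now stands apart from two other groups at this position, not just from benzyloxycarbonyl. Those two groups are not separated, as hydroxy in place of benzyloxycarbonyl gives a number 7.1 percentage points higher from compound 1 to compound 3 (within the scatter). Nothing at hand accounts for these differences.

Going by these compounds, whether an amine or a carboxylic acid on this carbon would match compound 2 remains open. Also open, on these data alone, is whether the sulfur matters, which a plain propyl chain would test.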